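Swapping the Ether Branch: Isopropyl to Pentan-3-yl

A few compounds are considered here, and "the series" means these few. Any claim that something is new, unique, unknown or untested is made for them only; others in the source may bear on it.

Three compounds share one core and differ only in the group on a saturated chain carbon bound to an oxygen on an aromatic ring. Compound 1 `O=C(/C=C/c1ccc(O)cc1)c1c(O)cccc1OCC1CCCC1` gives 3410 nM in a functional assay on MDA-MB-231 cells (Homo sapiens) for antiproliferative activity, read by sulforhodamine B assay; on this read-out higher numbers stand for weaker inhibition of growth and lower numbers for stronger inhibition of growth. Compound 2 `CC(C)(C)CCOc1cccc(O)c1C(=O)/C=C/c1ccc(O)cc1` gives 2380 nM, and compound 3 `CC(C)COc1cccc(O)c1C(=O)/C=C/c1ccc(O)cc1` gives 3520 nM, the highest of the three numbers, although every gap among them sits within the scatter: a 1.4-fold lower number from compound 1 to compound 2 (0.16 log units; within the scatter), a 1.0-fold higher number from compound 1 to compound 3 (0.01 log units; within the scatter) and a 1.5-fold higher number from compound 2 to compound 3 (0.17 log units; within the scatter). Compound 4 `CCC(CC)COc1cccc(O)c1C(=O)/C=C/c1ccc(O)cc1` carries pentan-3-yl in place of isopropyl on a saturated chain carbon bound to an oxygen on an aromatic ring. The three measured swaps at this position all stayed within the scatter, so no step beyond the scatter is expected for this one either. Compound 4 is therefore estimated at 3000 nM, between 1500 nM and 6500 nM, an expected step of a 1.2-fold lower number from compound 3 to compound 4 (0.07 log units; within the scatter).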

Compound 4, concentration for 50% growth inhibition: 3130 nM
For compound 4 the middle estimate is 1.0-fold (0.02 log units) below the measured one, and the stated range covers the measured number.
By their numbers in this assay, from the lowest: compounds 2, 4, 1 and 3 (each within the scatter of the next).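

In this assay, the larger pentan-3-yl brings no step beyond the scatter, with a 1.1-fold lower number from compound 3 to compound 4 (0.05 log units; within the scatter), a 1.3-fold higher number from compound 2 to compound 4 (0.12 log units; within the scatter) and a 1.1-fold lower number from compound 1 to compound 4 (0.04 log units; within the scatter). Every pair among the four compounds now lies within the scatter, so isopropyl, neopentyl, cyclopentyl and pentan-3-yl cannot be told apart at this position. Nothing available explains this result. Going by these compounds, whether a group carrying an amine or a carboxylic acid, or a much longer chain, would give a step beyond the scatter here remains open.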